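The compounds below may be only part of what the source reports. "The series", "measured", "known", "first", "only" and "open" are said of these compounds alone.

Measured compounds:
- compound 1, `N#Cc1ccc(Nc2ncc(Cc3c(F)cccc3F)o2)cc1`: 8000 nM
- compound 2, `N#Cc1ccc(Nc2ncc(Cc3c(F)cc(F)cc3F)o2)cc1Cl`: 7000 nM
- compound 3, `CCc1cc(F)c(Cc2cnc(Nc3ccc(C#N)c(Cl)c3)o2)c(F)c1`: 10000 nM

In an ADME assay on MT2 cells (Homo sapiens) for inhibition (a higher number here means that more compound is tolerated, a lower number that less compound is tolerated), the three numbers lie within the scatter of one another; compound 3 gives the highest of them, but its distance to compound 1 and to compound 2 is no larger than repeated measurements usually show. Among the compounds with values here, the one step that can be traced between neighbours, a 1.4-fold higher number from compound 2 to compound 3 (0.15 log units; within the scatter), is the replacement of a fluoro on an aromatic carbon by ethyl, and it stayed within the scatter.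

Compound 4, `N#Cc1ccc(Nc2ncc(Cc3c(F)cc(CC4CC4)cc3F)o2)cc1Cl`, differs from compound 3 in cyclopropyl in place of methyl on a saturated chain carbon bound to an aromatic carbon. Within the data shown here, this change has no direct precedent among the measured compounds. The nearest guide is the step from compound 2 to compound 3, where a larger carbon group on the same aromatic ring left this assay unmoved. On that basis no step beyond the scatter is expected in this assay for compound 4, in either direction. The step of no change at the digits printed from compound 3 to compound 4 (within the scatter) is therefore estimated as essentially flat. Compound 4 is expected to give about 10000 nM in this assay, with a range from 5000 nM to 20000 nM.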

Compound 4, half-maximal cytotoxic concentration: 29000 nM
For compound 4 the middle estimate is 2.9-fold (0.46 log units) below the measured one; the whole stated range lies below it.
By their numbers in this assay, from the lowest: compounds 2, 1 and 3 (each within the scatter of the next); then compound 4.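

In this assay, the place on the aromatic ring that had stayed within the scatter now gives a clear response: cyclopropyl in place of methyl on a saturated chain carbon bound to an aromatic carbon brings a 2.9-fold higher number from compound 3 to compound 4 (0.46 log units; beyond the scatter), and cyclopropylmethyl in place of fluoro on an aromatic carbon brings a 4.1-fold higher number from compound 2 to compound 4 (0.62 log units; beyond the scatter). Set against a 1.4-fold higher number from compound 2 to compound 3 (0.15 log units; within the scatter), which stayed within the scatter, this shows that the number at this place is not fixed for every carbon group, since ethyl and cyclopropylmethyl do not read alike here. Nothing available explains why the cyclopropyl ring has this effect on the number.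

The compounds shown cannot separate the ring itself from the greater length of the group, as a propyl or butyl chain would be needed to tell those two readings apart. On these data alone, it also stays open whether the rise continues with a cyclobutyl or cyclopentyl ring on the same carbon, and whether it survives an amine or a hydroxyl group on the chain.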